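This account rests on a few compounds, and the source may have more. Where it says the series, first, only, none or still open, it means among the compounds named here.

Values in a functional assay on the whole organism (strain Swiss CD-1) with Mus musculus as the target, with a stated time of 2 h; a lower number here means that less compound is needed, a higher number that more compound is needed for the effect:
- compound 1 `COCC(C(=O)N1CCN(c2cccc(Cl)c2)CC1)N1C(=O)CCC1=O`: 26.1 mg/kg
- compound 2 `COCC(C(=O)N1CCN(c2cccc(C)c2)CC1)N1C(=O)CCC1=O`: 47.7 mg/kg
- compound 3 `COCC(C(=O)N1CCN(c2ccc(C)cc2)CC1)N1C(=O)CCC1=O`: 21.1 mg/kg

Compound 3 stands level with compound 1 within the scatter, as the data show a 1.2-fold lower number from compound 1 to compound 3 (0.09 log units; within the scatter). Against compound 2 the data show a 2.3-fold lower number from compound 2 to compound 3 (0.35 log units; beyond the scatter).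

Next is compound 4 `COCC(C(=O)N1CCN(c2ccc(C(F)(F)F)cc2)CC1)N1C(=O)CCC1=O`, with trifluoromethyl in place of methyl on an aromatic carbon, para to a large group: trifluoromethyl in place of methyl on an aromatic carbon. Going by the values given here, no measured compound carries trifluoromethyl, so the read-across is indirect. The nearest measured exchange on an aromatic carbon is methyl in place of chloro, with a 1.8-fold higher number from compound 1 to compound 2 (0.26 log units; within the scatter). Among the compounds with values here, the largest step so far is a 2.3-fold lower number from compound 2 to compound 3 (0.35 log units; beyond the scatter), and it is modest. Going by these compounds, on these steps, no clear shift is expected in this assay, and the direction stays open. The expected step is a 1.2-fold higher number from compound 3 to compound 4 (0.07 log units; within the scatter), which would stay within the scatter. Compound 4 is estimated at 25 mg/kg, with an expected range of 12 mg/kg to 55 mg/kg.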

Compound 4, dose for half-maximal effect: 22.4 mg/kg
Compound 4: middle estimate off by 1.1-fold (0.05 log units), on the high side, within the range that was stated.
By their numbers in this assay, from the lowest: compounds 3, 4, 1 and 2 (each within the scatter of the next, the first and the last beyond it).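

On an aromatic carbon para to a large group, trifluoromethyl in place of methyl gives a 1.1-fold higher number from compound 3 to compound 4 (0.03 log units; within the scatter) in this assay, so the two groups cannot be told apart at this position. Until now, this position had been seen only with methyl, and the series had shown no fluorinated group; this place on the ring now holds trifluoromethyl with the number still level with that of the methyl compound. No measurement at hand accounts for this lack of change.

The compounds shown leave open whether an amine or a carboxylic acid on this aromatic carbon would also leave the number level. Also open, going by these compounds, is whether a 3-trifluoromethylphenyl group would lose ground as the methyl pair does, with a 2.3-fold lower number from compound 2 to compound 3 (0.35 log units; beyond the scatter).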